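The source may hold more compounds than are shown below. What is called first, only, known or untested is meant among the compounds shown, and "the series" means these compounds.

Compound 1 `CCOC(=O)C(=O)N(Cc1cc(F)cc(F)c1)c1ccc2c(c1)OC(C)(CO)CN2C`, compound 2 `CCOC(=O)CN(Cc1cc(F)cc(F)c1)c1ccc2c(c1)N(C)CC(C)(COc1ccc(C(=N)N)cc1)O2` and compound 3 `CCOC(=O)CN(Cc1cccc(F)c1)c1ccc2c(c1)N(C)CC(C)(COc1ccc(C#N)cc1)O2` share one core and were tested in a functional assay on HeLa cells (Homo sapiens) for antiproliferative activity, read by cell counting, with a stated time of 4 days; a higher number here means a weaker inhibitor, a lower number a stronger inhibitor. In this assay compound 1 gives 44000 nM. In this assay compound 2 gives 4500 nM. For compound 3 the assay reports only a limit, > 100000 nM, and not a number. That limit is the limit of > 100000 nM in this assay, at which 1 of the 3 values shown sits, so compound 3 stands at the weak end of the values shown. Compound 4 `CCOC(=O)CN(Cc1cccc(F)c1)c1ccc2c(c1)N(C)CC(C)(COc1ccc(C(=N)N)cc1)O2` has not yet been tested. It differs from compound 3 in one place, (a group of 3 heavy atoms (1 carbon, 2 nitrogen; no ring) in place of a group of 2 heavy atoms (1 carbon, 1 nitrogen; no ring), on an aromatic carbon), the cyano group being replaced on an aromatic carbon of a six-membered aromatic ring of carbon only, para to a large group. Compound 2 also carries the entering group of 3 heavy atoms, and in this assay compound 2 gives 4500 nM. On that basis the step from compound 3 to compound 4 is expected to be large and toward a stronger inhibitor, an at least 12-fold lower number from compound 3 to compound 4 (1.09 log units; beyond the scatter). Compound 4 is expected to give 8000 nM, within a range from 2000 nM to 40000 nM.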

Compound 4, half-maximal inhibitory concentration: 4600 nM
The estimate for compound 4 lay 1.7-fold (0.24 log units) above the measured number; low and high end bracket the measured number.
By their numbers in this assay, from the lowest: compounds 2 and 4 (each within the scatter of the next); then compound 1. At a limit, above all of these: compound 3.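

In this assay, putting the group of 3 heavy atoms in place of the cyano group, on an aromatic carbon para to a large group, gives an at least 21-fold lower number from compound 3 to compound 4 (1.33 log units; beyond the scatter), so this position has a clear effect on the number when the rest of the molecule stays the same. That step gives only a minimum size, because the value for compound 3 is a limit and not a number: the limit of > 100000 nM in this assay, at which 1 of the 4 values shown sits. The other step, hydrogen in place of fluoro on an aromatic carbon, gives a 1.0-fold higher number from compound 2 to compound 4 (0.01 log units; within the scatter), so this fluoro change makes no difference that can be told from the scatter.

The compounds shown cover only these two groups at the para position, so it remains open how a simple amine or a carboxylic acid would behave there. From the compounds shown here alone, it also remains open how much further the number would move with a longer chain carrying the same end group.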